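The source may report more compounds than this note shows. Statements on the series, on what has been measured and on what is new or still open speak of the compounds shown alone.

Measured so far in a functional assay (aorta) for antagonist activity, with Oryctolagus cuniculus as the target; on this read-out higher numbers stand for weaker inhibition and lower numbers for stronger inhibition:

compound 1 `O=C(O)c1c(Oc2ccc(-c3ccccc3-c3nn[nH]n3)cc2)c(C2CC2)nc2ccc(F)cc12` gives 0.61 nM
compound 2 `O=C(O)c1c(Oc2ccc(-c3ccccc3-c3nn[nH]n3)cc2)c(C2CC2)nc2ncccc12` gives 0.76 nM
compound 3 `CCc1nc2ccccc2c(C(=O)O)c1Oc1ccc(-c2ccccc2-c2nn[nH]n2)cc1` gives 0.12 nM

Compound 1 and compound 2 lie within the scatter of each other. Compound 3 alone stands apart from compound 1, with a lower number beyond the scatter, which means stronger inhibition.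

Compound 4 `COc1ccc2nc(C3CC3)c(Oc3ccc(-c4ccccc4-c4nn[nH]n4)cc3)c(C(=O)O)c2c1` has not been measured yet. It keeps the core of compound 1 and changes one group: methoxy in place of fluoro on an aromatic carbon of a six-membered aromatic ring of carbon only (methoxy in place of fluoro on an aromatic carbon).

Within the data shown here, no two measured compounds differ in one place only, so no measured step speaks directly to this swap. Among the measured compounds shown here, the only guide is indirect: compound 2 at 0.76 nM carries no fluoro, yet its value stays within the scatter of that of compound 1. On this thin evidence, no step beyond the scatter is expected in this assay, and neither direction is favoured. The expected step is a 1.1-fold higher number from compound 1 to compound 4 (0.06 log units; within the scatter) and it is estimated to stay within the scatter. For compound 4 the estimated value is 0.7 nM with an expected range of 0.3 nM to 1.6 nM on this read-out.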

Compound 4, antagonist equilibrium constant: 0.2 nM
Compound 4: the middle estimate sits 3.5-fold (0.54 log units) above what was measured; measured number below the stated range.
By their numbers in this assay, from the lowest: compounds 3 and 4 (each within the scatter of the next); then compounds 1 and 2 (each within the scatter of the next).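

In this assay the group on this aromatic carbon matters: methoxy in place of fluoro gives a 3.1-fold lower number from compound 1 to compound 4 (0.48 log units; beyond the scatter) and so moves the read-out toward stronger inhibition. Among these compounds, this is the first step that differs in one place only, and it shows directly that the position, on a six-membered aromatic ring of carbon only within a fused system of two rings, tolerates methoxy and responds to the change of group. The data at hand offer nothing that accounts for this step, so the result stands as an observation on one pair.

As far as these compounds go, it remains open how far this position tolerates other groups, such as ethoxy, hydroxy or an amine, and whether a longer chain on the oxygen would hold the gain seen with methoxy. From the compounds shown here alone, it is also open whether methoxy at this position would give a similar step on a version of the core with ethyl in place of cyclopropyl, and whether the same step would appear in any other assay.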